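Hydroxyl for methyl on the alkylamino chain

This account rests on a few compounds, and the source may have more. Where it says the series, first, only, none or still open, it means among the compounds named here.

Within the data shown here, in an assay on isolated protein for inhibition of serine/threonine-protein kinase TNNI3K (Homo sapiens) (a higher number here means a weaker inhibitor, a lower number a stronger inhibitor), compound 2 `CC(C)CNc1cc(Oc2ccc(NC(=O)Nc3cccc(C(F)(F)F)c3)cc2)ncn1` gives 50 nM, the higher of the two numbers so far; its nearest neighbour compound 1 `CCNc1cc(Oc2ccc(NC(=O)Nc3cccc(C(F)(F)F)c3)cc2)ncn1` gives 25 nM, and the gap between the two lies within the scatter. Compound 3 `C[C@H](O)CNc1cc(Oc2ccc(NC(=O)Nc3cccc(C(F)(F)F)c3)cc2)ncn1` is the next member of the series and has not yet been measured in this assay. It differs from compound 2 as 1-hydroxyethyl in place of isopropyl on a saturated chain carbon bound to a nitrogen on an aromatic ring. Among the measured compounds shown here, the only measured step, a 2.0-fold higher number from compound 1 to compound 2 (0.30 log units; within the scatter), concerns a change of the same chain at the same place, but it swaps one carbon group for another and adds no donor or acceptor, so it speaks only indirectly to the present change. For the measured compounds named here, nothing measured so far points to a large move in either direction, and the expectation is therefore a step close to no change, within the scatter, for compound 3: a 1.3-fold lower number from compound 2 to compound 3 (0.10 log units; within the scatter). On that basis compound 3 is estimated at 40 nM in this assay, with a range from 12 nM to 130 nM.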

Compound 3, half-maximal inhibitory concentration: 32 nM
The estimate for compound 3 lay 1.3-fold (0.10 log units) above the measured number; the measured number falls inside the stated range.
By their numbers in this assay, from the lowest: compounds 1, 3 and 2 (each within the scatter of the next).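

In this assay, the hydrogen-bond donor and acceptor that enter with 1-hydroxyethyl, on a saturated chain carbon bound to a nitrogen on an aromatic ring, leave the number within the scatter (a 1.6-fold lower number from compound 2 to compound 3 (0.19 log units; within the scatter)). Among these compounds, until now the only change at this place had swapped one carbon group for another, so this is the first sign that a hydroxyl can stand on this chain without a step beyond the scatter, and the comparison with the shorter chain of compound 1 reads the same way (a 1.3-fold higher number from compound 1 to compound 3 (0.11 log units; within the scatter)). No other measurement is at hand that bears on this result.

The compounds shown leave open what the mirror-image 2-hydroxypropyl chain would give, and so whether the defined stereocentre counts for anything at this place. They also leave open whether a methoxy group or an amine in place of the hydroxyl, or a longer chain carrying a hydroxyl, would move the number in this assay beyond the scatter, since all three chains so far lie within it of one another.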